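The source may report more compounds than this note shows. Statements on the series, on what has been measured and on what is new or still open speak of the compounds shown alone.

Compound 1 `CN1CCN(c2ccc3nc(-c4ccc(-c5ccccc5)s4)c(-c4ccncc4)n3n2)CC1` was examined in an ADME assay on HFF cells (Homo sapiens) for cytotoxicity, read by resazurin assay, with a stated time of 96 h (a higher number here means that more compound is tolerated, a lower number that less compound is tolerated), where compound 1 gives 6800 nM. Its companion compound 2 `CN1CCN(c2ccc3nc(-c4cccc(-c5ccccc5)c4)c(-c4ccncc4)n3n2)CC1` was run in the same way, and in this assay compound 2 gives 10900 nM. Within the data shown here, of these two numbers the one for compound 1 is the lesser, but the gap to compound 2 falls within the usual scatter of repeated measurements, so the two compounds cannot be separated on this basis. Among the measured compounds shown here, no step between two measured compounds differing in a single place is available.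

Compound 3 `CN1CCN(c2ccc3nc(-c4cccc(-c5ccsc5)c4)c(-c4ccncc4)n3n2)CC1` has not yet been measured. It carries the same atoms as compound 1, joined differently: 3-(thiophen-3-yl)phenyl in place of 5-phenylthiophen-2-yl on an aromatic carbon. The exchanged group keeps the same ring types, the same count of hydrogen-bond acceptors and no charge, so no large shift is anticipated. Since compound 2, which also presents a six-membered carbon ring bearing a further aromatic ring on this position, gives 10900 nM, a modest step from compound 1 to compound 3 of a 1.3-fold higher number from compound 1 to compound 3 (0.10 log units; within the scatter) is expected, within the scatter. Compound 3 is therefore estimated at 8500 nM, with a range from 4000 nM to 18000 nM.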

Compound 3, half-maximal cytotoxic concentration: 6300 nM
For compound 3 the middle estimate is 1.3-fold (0.13 log units) above the measured one; the range from low to high includes it.
By their numbers in this assay, from the lowest: compounds 3, 1 and 2 (each within the scatter of the next).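

In this assay, joining the same atoms differently on this aromatic carbon, with 3-(thiophen-3-yl)phenyl in place of 5-phenylthiophen-2-yl, gives a 1.1-fold lower number from compound 1 to compound 3 (0.03 log units; within the scatter), so this rearrangement of a five-membered and a six-membered aromatic ring does not separate the two compounds. Thiophen-3-yl in place of phenyl on an aromatic carbon gives a 1.7-fold lower number from compound 2 to compound 3 (0.24 log units; within the scatter), which also stays within the scatter and shows that, among these three compounds, neither exchange produces a readable difference in this assay. Nothing measured here offers an explanation for this result.

From the compounds shown here alone, all three compounds carry two linked aromatic rings at this position, so it remains open whether an amine such as piperidin-4-yl or a carboxylic acid there would move the number beyond the scatter. Also open is whether a lone phenyl, carrying no further ring, would give a number close to those of these compounds.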